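Linker swap at the aryl ether of compound 2

A few compounds are considered here, and "the series" means these few. Any claim that something is new, unique, unknown or untested is made for them only; others in the source may bear on it.

Measured so far in an assay on RKO cells for inhibition of ubiquitin carboxyl-terminal hydrolase 7 (Homo sapiens), read by a luciferase reporter, with a stated time of 18 h; a higher number here means that more compound is needed for the effect, a lower number that less compound is needed:
compound 1 `Cc1cc(Cl)cc(-c2ccnc3cc(CN4C(=O)C5CC5C4=O)sc23)c1O[C@@H]1CCNC[C@@H]1C`: 170 nM
compound 2 `Cc1cc(Cl)cc(-c2ccnc3cc(CN4C(=O)C5C(C4=O)C5(C)C)sc23)c1OC1CCCNC1`: 250 nM
compound 3 `Cc1cc(Cl)cc(-c2ccnc3cc(CN4C(=O)CCC4=O)sc23)c1O[C@H]1C[C@H](N)C1`: 150 nM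

Compound 2 carries the highest of the three numbers, yet its gap to compound 1 and its gap to compound 3 both lie within the scatter, so no order among the three is claimed. Among the compounds with values here, none of the three pairs differs in a single place, so no measured step is available as a guide.

Compound 4 `Cc1cc(Cl)cc(-c2ccnc3cc(CN4C(=O)C5C(C4=O)C5(C)C)sc23)c1CC1CCCNC1` is not yet measured. It differs from compound 2 as follows: (piperidin-3-yl)methyl in place of (piperidin-3-yl)oxy on an aromatic carbon. The change keeps the ring and its donor and removes one acceptor.

Within the data shown here, with no measured step at this position, the expected step of a 1.6-fold higher number from compound 2 to compound 4 (0.20 log units; within the scatter) is small, toward a higher number, and possibly not beyond the scatter. For compound 4 the estimate in this assay is 400 nM, with a range of 150 nM to 1200 nM.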

Compound 4, half-maximal effective concentration: 130 nM
Compound 4: the middle estimate sits 3.1-fold (0.49 log units) above what was measured; measured number outside the range, below it.
By their numbers in this assay, from the lowest: compounds 4, 3, 1 and 2 (each within the scatter of the next).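

Within the data shown here, the step of a 1.9-fold lower number from compound 2 to compound 4 (0.28 log units; within the scatter) is the first single-place comparison. In this assay, (piperidin-3-yl)methyl can therefore stand in place of (piperidin-3-yl)oxy on this aromatic carbon with no change beyond the scatter, so the oxygen of the (piperidin-3-yl)oxy group is not shown to be required for the effect. No evidence bears on the reason for this result. Still open, going by these compounds, is whether a secondary amine or a longer chain as the link at this carbon would read the same. Also open, on these data alone, is whether the swap carries over to the groups of compound 1 and compound 3.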